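A few compounds are considered here, and "the series" means these few. Any claim that something is new, unique, unknown or untested is made for them only; others in the source may bear on it.

Measured so far:
Compound 1, `N#CCCCn1c(Cn2c(=O)n(-c3ncccn3)c3ccncc32)cc2cc(Cl)ccc21`, in an ADME assay on HeLa cells (Homo sapiens) for cytotoxicity, read by ATP content, with a stated time of 3 days (on this read-out lower numbers stand for higher toxicity in this test and higher numbers for lower toxicity in this test), gives > 50000 nM, which is a limit of this test and not a number.
Compound 2, `N#CCCCn1c(Cn2c(=O)n(C3CC3)c3ccncc32)nc2nc(Cl)ccc21`, in this assay gives > 50000 nM, also a limit.
Compound 3, `CS(=O)(=O)CCCn1c(Cn2c(=O)[nH]c3ccncc32)cc2cc(Cl)ccc21`, in this assay gives > 50000 nM, again a limit.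

Compound 1 therefore stands at the limit of this assay rather than at a measured number, and the two other compounds stand at the same limit, so no order among the three can be drawn from these values. Compound 4, `COc1ccc(-n2c(=O)n(Cc3cc4cc(Cl)ccc4n3CCCC#N)c3cnccc32)c(F)c1`, differs from compound 1 in one place: 2-fluoro-4-methoxyphenyl in place of pyrimidin-2-yl on an aromatic nitrogen. Among the compounds with values here, no step between two measured compounds is available to size this change. Because the limit of > 50000 nM in this assay, at which 3 of the 3 values shown sit, holds for every measured value, the expectation for compound 4 is that it too sits at the limit rather than showing a step beyond the scatter. The expected step is a number no higher from compound 1 to compound 4 (the limit leaves the size open). Compound 4 is estimated at 50000 nM, within a range from 15000 nM to 150000 nM, and is most likely reported again only as a limit.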

Compound 4, half-maximal cytotoxic concentration: > 50000 nM
Compound 4 was reported as a limit; the forecaster's own chance of this, stated with the estimate: 75%; the middle value sits exactly at the limit.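

No step can be read from compound 1 to compound 4 in this assay, because both compounds sit at one shared limit and neither gives a number: the limit of > 50000 nM in this assay, at which 4 of the 4 values shown sit.

The compounds shown leave open at what concentration, if any, each becomes toxic to these cells, and whether 2-fluoro-4-methoxyphenyl in place of pyrimidin-2-yl changes that concentration at all.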